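Chloro for Hydrogen on the Core of Compound 1

The source may report more compounds than this note shows. Statements on the series, on what has been measured and on what is new or still open speak of the compounds shown alone.

Measured compounds:
compound 1 `O=C(CCSc1nc2ccccc2o1)N1CCCC1`, 5.1 mL/min/g
compound 2 `COc1ccc2oc(SCCC(=O)N3CCCC3)nc2c1`, 6.1 mL/min/g

In an ADME assay on microsomes from liver (Homo sapiens) for metabolic stability, read by LC-MS, using NADPH, with a stated time of 45 min, tested at 0.5 uM (a lower number here means slower removal, a higher number faster removal of the compound), compound 1 has the lowest of the two numbers; its nearest neighbour is compound 2, and the step of a 1.2-fold higher number from compound 1 to compound 2 (0.08 log units; within the scatter) lies within the scatter. Compound 3 `O=C(CCSc1nc2c(Cl)cccc2o1)N1CCCC1` differs from compound 1 by chloro in place of hydrogen on an aromatic carbon. For the measured compounds named here, the only measured step on this core, a 1.2-fold higher number from compound 1 to compound 2 (0.08 log units; within the scatter), changes a different group and was within the scatter, so no step beyond the scatter is expected in this assay. Compound 3 is estimated at 4.5 mL/min/g, within 2.5 mL/min/g to 8 mL/min/g, a step of a 1.1-fold lower number from compound 1 to compound 3 (0.05 log units; within the scatter).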

Compound 3, intrinsic clearance in a liver preparation (reported as CLH), per the amount of preparation that the assay uses: 15.8 mL/min/g
Beside the measured number, compound 3's estimate is 3.5-fold (0.55 log units) below it; measured number above the stated range.
By their numbers in this assay, from the lowest: compounds 1 and 2 (each within the scatter of the next); then compound 3.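

In this assay, for the compounds shown here, chloro in place of hydrogen on an aromatic carbon gives a 3.1-fold higher number from compound 1 to compound 3 (0.49 log units; beyond the scatter), whereas the only earlier step on this core, the methoxy change, gave a 1.2-fold higher number from compound 1 to compound 2 (0.08 log units; within the scatter). This shows that a single chlorine atom at this place, ortho to a fused ring, is enough to move the number beyond the scatter toward faster removal. Nothing measured here accounts for this rise. Going by these compounds, whether fluoro, methyl or an amine at this same place would move the number as chloro does stays open. So does whether chloro elsewhere on the core of compound 1 would do the same.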